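A few compounds are considered here, and "the series" means these few. Any claim that something is new, unique, unknown or untested is made for them only; others in the source may bear on it.

Measured so far:
compound 1 `O=C(CCCCCCc1ccccc1)c1nc(C(=O)C(F)(F)F)co1` gives 123 nM
compound 2 `CS(=O)(=O)c1coc(C(=O)CCCCCCc2ccccc2)n1` gives 389 nM
compound 3 `O=Cc1coc(C(=O)CCCCCCc2ccccc2)n1` gives 1510 nM

All three share one core and differ only in the group attached to it. In an assay on HEK-293T cells for inhibition of diacylglycerol lipase-alpha (Homo sapiens), read by colorimetric assay (on this read-out higher numbers stand for weaker inhibition and lower numbers for stronger inhibition), compound 3 stands highest of the three numbers: the step of a 3.9-fold higher number from compound 2 to compound 3 (0.59 log units; beyond the scatter) is modest, and the step of a 12-fold higher number from compound 1 to compound 3 (1.09 log units; beyond the scatter) is large, so compound 3 is the weakest inhibitor among them.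

Compound 4 `CN(C)C(=O)c1coc(C(=O)CCCCCCc2ccccc2)n1` is not yet measured. It differs from compound 3 in one place: dimethylamino in place of hydrogen on a carbonyl carbon. The same spot on the core has already been varied among the measured compounds, and each change moved the number beyond the scatter: a 3.2-fold higher number from compound 1 to compound 2 (0.50 log units; beyond the scatter), a 12-fold higher number from compound 1 to compound 3 (1.09 log units; beyond the scatter) and a 3.9-fold higher number from compound 2 to compound 3 (0.59 log units; beyond the scatter). These steps show that what sits on this carbon sets the potency over a wide span, but none of them involves a dimethylamino group, so the direction of the new step is not fixed by the data. Compound 3 already stands at the weak end of the series, and a further modest weakening is expected in this assay, a step of a 2.0-fold higher number from compound 3 to compound 4 (0.30 log units; within the scatter). Compound 4 is therefore estimated at 3000 nM, within a range from 800 nM to 12000 nM.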

Compound 4, half-maximal inhibitory concentration: 3390 nM
The estimate for compound 4 lay 1.1-fold (0.05 log units) below the measured number; the range from low to high includes it.
By their numbers in this assay, from the lowest: compound 1; then compound 2; then compound 3; then compound 4.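

Replacing the hydrogen of the formyl group with dimethylamino turns it into dimethylcarbamoyl and weakens inhibition further in this assay (a 2.2-fold higher number from compound 3 to compound 4 (0.35 log units; beyond the scatter)), making compound 4 the weakest inhibitor of the four. Three of the compounds keep a carbonyl carbon at this spot and differ only in what it carries, yet their potency still spreads widely (a 28-fold higher number from compound 1 to compound 4 (1.44 log units; beyond the scatter)), so the carbonyl by itself does not fix the number, and the group attached to it matters as well. Dimethylcarbamoyl also falls well short of the methylsulfonyl group (an 8.7-fold higher number from compound 2 to compound 4 (0.94 log units; beyond the scatter)), although nothing measured here bears on why the groups fall in this order.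

The compounds shown leave open how far the dimethylamino result extends to other groups on this carbonyl carbon, such as a simple amino group, a hydroxyl group that would make a carboxylic acid, or a methoxy group that would make a methyl ester. They also leave open whether a ring amine such as morpholine would sit near compound 4 or nearer compound 1.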